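Homologation at the nitrile end of a phenol ether series

The source may report more compounds than this note shows. Statements on the series, on what has been measured and on what is new or still open speak of the compounds shown alone.

Measured compounds in an assay on isolated protein for inhibition of leukotriene B4 receptor 1 (Homo sapiens), tested at 10 uM; on this read-out higher numbers stand for more inhibition at the one concentration tested (going by the name of the read-out) and lower numbers for less inhibition:
compound 1, `CCc1cc(C(C)=O)c(O)cc1OCCCCC#N`: 92%
compound 2, `CCc1cc(C(C)=O)c(O)cc1OCCCC(C)(C)C#N`: 85%

Among the measured compounds shown here, compound 2 holds the lower of the two numbers in this assay, with compound 1 its only neighbour; the step of a number 7 percentage points lower from compound 1 to compound 2 (within the scatter) is within the scatter, so the two compounds cannot be ordered on these data.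

Compound 3, `CCc1cc(C(C)=O)c(O)cc1OCCCCC(C)(C)C#N`, is not yet measured. The change from compound 2 is 2-cyano-2-methylpropyl in place of 1-cyano-1-methylethyl on a saturated chain carbon, three bonds along the chain from an oxygen on an aromatic ring.

For the measured compounds named here, only one measured step exists, a number 7 percentage points lower from compound 1 to compound 2 (within the scatter), and it concerns the same place on the chain but a different change, with no lengthening of the chain. Going by the values given here, no measured step shows what one further chain carbon does here. On that basis the step of a number 2 percentage points lower from compound 2 to compound 3 (within the scatter) is expected to stay within the scatter, with no direction assigned. Compound 3 is therefore estimated at 83% in this assay, in the range 60% to 100%.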

Compound 3, a percentage reported as inhibition, at one concentration (the size of the read-out at that concentration, not a potency): 79%
Compound 3: the middle estimate sits 4 percentage points above what was measured, within the range that was stated.
By their numbers in this assay, from the lowest: compounds 3, 2 and 1 (each within the scatter of the next, the first and the last beyond it).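

In this assay, 2-cyano-2-methylpropyl in place of 1-cyano-1-methylethyl gives a number 6 percentage points lower from compound 2 to compound 3 (within the scatter) and so cannot be told apart from no change on these data. Among the compounds shown here, the combined change, 1-cyano-1-methylethyl in place of cyano on a saturated chain carbon, four bonds along the chain from an oxygen on an aromatic ring, gives a number 13 percentage points lower from compound 1 to compound 3 (beyond the scatter) and is the only step so far to lie beyond the scatter, though it remains modest. No other data bear on the reason for this step.

From the compounds shown here alone, all three compounds keep the nitrile, so it remains open whether a carboxylic acid or an amine at that chain end would retain the inhibition. For the compounds shown here, a longer chain is also open, and readings at one concentration give no potency for any compound.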